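The source may report more compounds than this note shows. Statements on the series, on what has been measured and on what is new or still open speak of the compounds shown alone.

Compound 1 `Cc1cc(C(F)(F)F)cc(NC[C@@H]2CC3(CC3)CN2C(=O)c2nc(C)sc2-c2ccccc2)n1` is measured in a functional assay on CHO cells for antagonist activity at Orexin/Hypocretin receptor type 1 (Homo sapiens), read by FLIPR and calcium flux (a higher number here means a more potent compound, by a factor of ten per unit of this negative logarithm, a lower number a less potent compound), where compound 1 gives 7.8. Two companions share the same core: compound 2 `Cc1ccc(-n2nccn2)c(C(=O)N2CC3(CC3)C[C@H]2CNc2ccc(Cl)cn2)c1` gives 8.1 in this assay, and compound 3 `N#Cc1ccc(-c2ncccn2)c(C(=O)N2CC3(CC3)C[C@H]2CNc2ccc(C(F)(F)F)cn2)c1` gives 8. The gaps between compound 1 and each of these lie within the usual scatter, so the three cannot be told apart on these numbers. Compound 4 `Cc1cc(C)nc(NC[C@@H]2CC3(CC3)CN2C(=O)c2nc(C)sc2-c2ccccc2)n1` differs from compound 1 in one place: 4,6-dimethylpyrimidin-2-yl in place of 6-methyl-4-(trifluoromethyl)pyridin-2-yl on an amine nitrogen. For the measured compounds named here, no measured pair shows this exact change, so the expected step from compound 1 to compound 4 in this assay is small, a number 0.20 log units lower from compound 1 to compound 4 (within the scatter), likely not beyond the scatter. Compound 4 is therefore estimated at 7.6, with a range from 7 to 8.2.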

Compound 4, negative logarithm of the antagonist equilibrium constant: 7.5
The estimate for compound 4 lay 0.10 log units above the measured number, and the stated range covers the measured number.
By their numbers in this assay, from the lowest: compounds 4, 1, 3 and 2 (each within the scatter of the next, the first and the last beyond it).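

In this assay, for the compounds shown here, this is the first comparison in which only one place changes: the group on the amine nitrogen. Replacing 6-methyl-4-(trifluoromethyl)pyridin-2-yl with 4,6-dimethylpyrimidin-2-yl gives a number 0.30 log units lower from compound 1 to compound 4 (within the scatter), so this change, which removes the trifluoromethyl group and adds a second ring nitrogen, cannot be told apart from repeat-measurement noise. No measurement here offers an explanation for this result. Going by these compounds, it remains open whether an ethyl chain or a carboxylic acid-bearing group on that nitrogen would keep the number. On these data alone, whether the same swap behaves alike with other groups elsewhere on the core also remains open.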